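Aryl carbamate selenocyanates: methyl for methoxy

The compounds below may be only part of what the source reports. "The series", "measured", "known", "first", "only" and "open" are said of these compounds alone.

Three anilides carrying a selenocyanate or a diselenide have been measured in a functional assay on CCRF-CEM cells (Homo sapiens) for cytotoxicity, read by MTT assay, with a stated time of 72 h; a lower number here means a stronger inhibitor of growth, a higher number a weaker inhibitor of growth. Compound 1 `COc1ccc(OC(=O)Nc2ccc([Se]C#N)cc2)cc1` gives 41500 nM. Compound 2 `CCCOC(=O)Nc1ccc([Se]C#N)cc1` gives 38400 nM. Compound 3 `CCOC(=O)Nc1ccc([Se][Se]c2ccc(NC(=O)OCC)cc2)cc1` gives 49500 nM. Of the three numbers, that of compound 1 lies nearest to that of compound 2 and furthest from that of compound 3, and both gaps fall within the usual scatter of this assay, so the three carbamates cannot be told apart on these data. Among the measured compounds shown here, no pair among them differs in a single place, so no step can be stated.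

Compound 4 `Cc1ccc(OC(=O)Nc2ccc([Se]C#N)cc2)cc1` is the next member: methyl in place of methoxy on an aromatic carbon, on the carbon para to a large group. The three measured carbamates, with propyl, ethyl and methoxyphenyl esters, all sit close together, and nothing here points to a change beyond the scatter. The step from compound 1 to compound 4 is therefore estimated as a 1.0-fold lower number from compound 1 to compound 4 (0.02 log units; within the scatter). For compound 4 the expected value in this assay is 40000 nM, with a range from 20000 nM to 80000 nM.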

Compound 4, concentration for total growth inhibition: 44700 nM
Compound 4: middle estimate off by 1.1-fold (0.05 log units), on the low side; the range from low to high includes it.
By their numbers in this assay, from the lowest: compounds 2, 1, 4 and 3 (each within the scatter of the next).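

In this assay, among the compounds shown here, methyl in place of methoxy on an aromatic carbon, para to a large group, gives a 1.1-fold higher number from compound 1 to compound 4 (0.03 log units; within the scatter), the first step that can be read at all. At this position, then, an oxygen and a hydrogen-bond acceptor can go without any difference this assay can resolve, so the methoxy group is not required for the level of growth inhibition seen with compound 1. No measurement shown here offers an explanation for this flat step.

Two close neighbours at one position do not show whether this position is insensitive in general. As far as these compounds go, an amine, a carboxylic acid or a longer chain on the same carbon could still move the number beyond the scatter, and the effect of leaving this carbon unsubstituted remains open.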